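Swapping a hydroxymethyl for a carboxy on the side chain

This account rests on a few compounds, and the source may have more. Where it says the series, first, only, none or still open, it means among the compounds named here.

Of the compounds shown here, three built on one shared core have been tested in an assay on 32D cells for inhibition of interleukin-15 (Mus musculus), read by resazurin assay, with stated times of 30 min and 2.5 days, in the presence of a further agent that is not named here; on this read-out higher numbers stand for weaker inhibition and lower numbers for stronger inhibition. Compound 1 `Cn1nc(Cc2nnc(SCCCCCCCC(=O)Nc3ccc(Cl)cc3Cl)n2CCCO[Si](C)(C)C(C)(C)C)c2ccccc2c1=O` gives in this assay only a limit of the assay, > 30000 nM. Compound 2 `CN(C)CCCn1c(Cc2nn(C)c(=O)c3ccccc23)nnc1SCCCCCCCC(=O)Nc1ccc(Cl)cc1Cl` gives 3700 nM in this assay. Compound 3 `Cn1nc(Cc2nnc(SCCCCCCCC(=O)Nc3ccc(Cl)cc3Cl)n2CCCO)c2ccccc2c1=O` likewise reaches in this assay only a limit, > 30000 nM. Compound 3 therefore stands at the limit of > 30000 nM in this assay, at which 2 of the 3 values shown sit, the weak end of what the numbers show. Two measured steps involve this same side chain: an at least 8.1-fold lower number from compound 1 to compound 2 (0.90 log units; beyond the scatter) and an at least 8.1-fold higher number from compound 2 to compound 3 (0.90 log units; beyond the scatter), both beyond the scatter, while a step that the two limits leave unreadable from compound 1 to compound 3 cannot be read. Compound 4 `Cn1nc(Cc2nnc(SCCCCCCCC(=O)Nc3ccc(Cl)cc3Cl)n2CCC(=O)O)c2ccccc2c1=O` differs from compound 3 by carboxy in place of hydroxymethyl on a saturated chain carbon, two bonds along the chain from an aromatic nitrogen. Within the data shown here, no measured step covers a carboxy at this place, so nothing points to compound 4 leaving the limit. The expected step is a number no higher from compound 3 to compound 4 (the limit leaves the size open), that is, no movement beyond the scatter. Compound 4 is thus estimated at 30000 nM, with a range from 8000 nM to 100000 nM, most likely again reported only as a limit.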

Compound 4, half-maximal inhibitory concentration: 23500 nM
Compound 4: the middle estimate sits 1.3-fold (0.11 log units) above what was measured; the measured number falls inside the stated range.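

In (this assay) a carboxy at this place gives compound 4 a measured number and not a limit, so it is the second compound in this side-chain series with a readable value, after compound 2. Against the two compounds held at a limit only floors can be read (an at least 1.2-fold lower number from compound 3 to compound 4 (0.10 log units; that floor lies within the scatter)) (an at least 1.2-fold lower number from compound 1 to compound 4 (0.10 log units; that floor lies within the scatter)), so no real change from hydroxymethyl to carboxy can be claimed. The comparison with the amine is readable (a 6.4-fold higher number from compound 2 to compound 4 (0.80 log units; beyond the scatter)), and it leaves compound 2, with its dimethylamino group, clearly ahead of the other three compounds.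

A primary amine or a pyrrolidine at this place would test whether the gain is specific to dimethylamino. A longer chain carrying the dimethylamino group would test whether the length of this chain matters.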